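The source may report more compounds than this note shows. Statements on the series, on what has been measured and on what is new or still open speak of the compounds shown alone.

Series notes, whole-animal inhibition. In a functional assay on the whole organism for inhibition, with Rattus norvegicus as the target (a lower number here means that less compound is needed, a higher number that more compound is needed for the effect), three compounds have been measured so far, and none of them returned a number. Compound 1, `CC1CC/C(=N\Nc2ccccc2)c2ncc(C#N)c(=O)n21`, gave only the limit > 1000 umol/kg. Compound 2, `CC1CC/C(=N\Nc2ccccc2F)c2ncc(C(=O)O)c(=O)n21`, likewise gave only the limit > 1000 umol/kg. Compound 3, `CCOc1ccc(N/N=C2\CC[C@@H](C)n3c2ncc(C(=O)O)c3=O)cc1`, stopped at the limit > 100 umol/kg. Compound 2 thus stands at the limit of > 1000 umol/kg in this assay, at which 2 of the 3 values shown sit, a bound it shares with compound 1, whereas compound 3 sits at the limit of > 100 umol/kg in this assay, at which 1 of the 3 values shown sits, a lower bound from which nothing further can be read. For the measured compounds named here, no pair of measured compounds differs in one place, so no measured step is available in this assay.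

The next compound, compound 4, `Cc1ccccc1N/N=C1\CCC(C)n2c1ncc(C(=O)O)c2=O`, differs from compound 2 by methyl in place of fluoro on an aromatic carbon. Going by the values given here, compound 2 itself is only a limit, so no step can be anchored on a number; given that every value seen so far is a limit, the expectation is that this change shifts the readout by nothing beyond the scatter and that compound 4 again reports a limit rather than a dose. Compound 4 is expected to give about 1500 umol/kg in this assay, with a range of 300 umol/kg to 5000 umol/kg. The estimated step that the limit leaves unreadable from compound 2 to compound 4 is expected to lie within the scatter.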

Compound 4, dose for 50% inhibition: > 100 umol/kg
Compound 4 gave a limit, no number; the forecaster's own chance of this, stated with the estimate: 85%; the middle value is on the limit's open side.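

In this assay compound 4 gave > 100 umol/kg, which is a limit and not a number. Compound 2 gave > 1000 umol/kg, also a limit, so no step can be read between compound 2 and compound 4. The compounds shown leave open what dose gives the effect for any of them, and whether methyl in place of fluoro changes it.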